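This account rests on a few compounds, and the source may have more. Where it says the series, first, only, none or still open, it means among the compounds named here.

Series notes. Compound 1 `Clc1cccc(CSc2nnc(-c3ccncc3)n2-c2ccccc2)c1` gives 9820 nM in a functional assay on HCT-116 cells (Homo sapiens) for inhibition, read by MTT assay, with a stated time of 48 h; on this read-out higher numbers stand for weaker inhibition and lower numbers for stronger inhibition. Compound 2 `O=C(CSc1nnc(-c2ccncc2)n1-c1ccccc1)N/N=C/c1ccccc1` gives 14700 nM in this assay. Compound 3 `O=C(CSc1nnc(-c2ccncc2)n1-c1ccccc1)N/N=C/c1ccc(O)cc1` reaches only a limit of this assay, > 50000 nM, so where it stands among the numbers shown is not fixed. Going by the values given here, the one measured step that bears on the unmeasured change is an at least 3.4-fold higher number from compound 2 to compound 3 (0.53 log units; beyond the scatter), and it is itself known only as a floor set by the limit of > 50000 nM in this assay, at which 1 of the 3 values shown sits. Compound 4 `O=C(CSc1nnc(-c2ccncc2)n1-c1ccccc1)N/N=C/c1ccc(F)cc1` is still to be measured; it differs from compound 3 by fluoro in place of hydroxy on an aromatic carbon. Since compound 2 without the hydroxy gives 14700 nM, the expected direction is toward stronger inhibition. Compound 4 is estimated at 20000 nM, with a range from 8000 nM to 50000 nM. The expected step is an at least 2.5-fold lower number from compound 3 to compound 4 (0.39 log units; beyond the scatter).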

Compound 4, half-maximal inhibitory concentration: 7040 nM
Compound 4: the middle estimate sits 2.8-fold (0.45 log units) above what was measured, and the stated range ends above it.
By their numbers in this assay, from the lowest: compounds 4, 1 and 2 (each within the scatter of the next, the first and the last beyond it). At a limit, above all of these: compound 3.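

In this assay the change from 4-hydroxyphenyl to 4-fluorophenyl gives an at least 7.1-fold lower number from compound 3 to compound 4 (0.85 log units; beyond the scatter), and that size is only a floor: the limit of > 50000 nM in this assay, at which 1 of the 4 values shown sits. The same aromatic carbon, para to a large group, also separates fluoro from hydrogen (a 2.1-fold lower number from compound 2 to compound 4 (0.32 log units; beyond the scatter)). A substituent here can therefore lower the number relative to hydrogen, so the loss seen with hydroxy does not extend to every replacement at this carbon.

From the compounds shown here alone, whether chloro, methoxy or an amine at this carbon would follow fluoro or hydroxy remains open. Going by these compounds, the true value of compound 3 also remains open.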